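The source may hold more compounds than are shown below. What is called first, only, known or untested is meant among the compounds shown, and "the series" means these compounds.

Measured so far:
compound 1, `Cc1cc(S(=O)(=O)/N=C(\N)N/N=C/C#Cc2ccccc2)c(SCc2ccccc2C(F)(F)F)cc1Cl`; in an ADME assay on HaCaT cells (Homo sapiens) for cytotoxicity, read by MTT assay, with a stated time of 72 h (on this read-out lower numbers stand for stronger inhibition and higher numbers for weaker inhibition), compound 1 gives 23000 nM.
compound 2, `Cc1cc(S(=O)(=O)/N=C(\N)N/N=C/C#Cc2ccccc2)c(SCc2ccc(C(F)(F)F)cc2)cc1Cl`; in this assay compound 2 gives "not determined" (no result reported).

Compound 2 therefore has no single number to stand on in this assay; the only numeric anchor in the series is compound 1, whose value in this assay lies high, that is, on the side of weak inhibition. Compound 1 and compound 2 share the whole core and the benzylsulfanyl arm and differ only in where the trifluoromethyl sits on that arm.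

Compound 3, `Cc1cc(S(=O)(=O)/N=C(\N)N/N=C/C#Cc2ccccc2)c(SCc2cccc3ccccc23)cc1Cl`, differs from compound 2 by naphthalen-1-yl in place of 4-(trifluoromethyl)phenyl on a saturated chain carbon bound to a sulfur. Among the measured compounds shown here, no measured pair covers this change, so no step size can be read off. The working expectation is that compound 3 stays in the weakly cytotoxic region that compound 1 marks with 23000 nM, with any shift relative to compound 1 not clearly beyond the scatter in either direction. Compound 3 is expected at 20000 nM, with a range from 7000 nM to 60000 nM. A limit-only result is a real possibility for compound 3 in this region.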

Compound 3, half-maximal inhibitory concentration: 5000 nM
Estimate against measurement, compound 3: 4.0-fold (0.60 log units) above; measured number outside the range, below it.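

In this assay, a 4.6-fold lower number from compound 1 to compound 3 (0.66 log units; beyond the scatter) gives the first readable size of a change at this position: the arm of compound 3 carries naphthalen-1-yl where the arm of compound 1 carries its trifluoromethyl-substituted phenyl group, and the number moves modestly but beyond the scatter, towards stronger inhibition. The group carried on this chain carbon therefore registers on this read-out, and the weak end marked by compound 1 does not hold for every arm on the shared core; the pair of compound 2 and compound 3 cannot be read, since compound 2 has no number, so the placement of the trifluoromethyl on the arm remains without a measured effect. No measurement at hand accounts for the shift seen with this change.

This single step joins two changes, the loss of the trifluoromethyl and the entry of a second aromatic ring, and the compounds shown do not separate them. Also open, going by these compounds, is how a plain phenyl or naphthalen-2-yl on the same chain carbon would read, and whether a carboxylic acid or an amine on that arm would keep the number near either value.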